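Cytotoxicity notes: hydroxy for amino on the shared core

The compounds below may be only part of what the source reports. "The series", "measured", "known", "first", "only" and "open" are said of these compounds alone.

Measured so far:
compound 1 `O=c1[nH]c(Nc2cc(Cl)cc(Cl)c2)nc2cc(Cl)ccc12`: > 25000 nM
compound 2 `O=c1[nH]c(Nc2cc(Cl)cc(Cl)c2)nc2cc([N+](=O)[O-])ccc12`: > 25000 nM
compound 3 `Nc1ccc2c(=O)[nH]c(Nc3cc(Cl)cc(Cl)c3)nc2c1`: > 25000 nM

Each of these values in an ADME assay on Vero cells (Chlorocebus sabaeus) for cytotoxicity, read by WST assay (on this read-out higher numbers stand for lower toxicity in this test and lower numbers for higher toxicity in this test), is a limit of the assay, not a number. Compound 3 therefore stands only at a limit, and the two other values shown are limits as well. The steps a step that the two limits leave unreadable from compound 1 to compound 2, a step that the two limits leave unreadable from compound 1 to compound 3 and a step that the two limits leave unreadable from compound 2 to compound 3 cannot be read, because of the limit of > 25000 nM in this assay, at which 3 of the 3 values shown sit.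

Compound 4 `O=c1[nH]c(Nc2cc(Cl)cc(Cl)c2)nc2cc(O)ccc12` differs from compound 3 by hydroxy in place of amino on an aromatic carbon. Going by the values given here, no measured step bears readably on this change, so no step beyond the scatter is expected in this assay; the estimated step that the limit leaves unreadable from compound 3 to compound 4 is small. Compound 4 is expected to give about 40000 nM, within 15000 nM to 120000 nM, most likely again only a limit.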

Compound 4, half-maximal cytotoxic concentration: > 25000 nM
Compound 4 gave a limit, no number; the forecaster's own chance of this, stated with the estimate: 80%; the middle value does not contradict the limit.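

Compound 4 gives only a limit (> 25000 nM). Going by these compounds alone, no step from compound 1, compound 2 or compound 3 to compound 4 can be read: the limit of > 25000 nM in this assay, at which 4 of the 4 values shown sit. The compounds shown leave open whether chloro, nitro, amino and hydroxy on the shared core differ at all in cytotoxicity.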